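Neopentyl in Place of Isopropyl on the Amine-Bearing Carbon

The source may hold more compounds than are shown below. What is called first, only, known or untested is meant among the compounds shown, and "the series" means these compounds.

Measured so far:
compound 1 `CC(C)C[C@H](N)C(=O)Nc1cc2cc[nH]c(=O)c2cc1Cl`, in an assay on isolated protein for inhibition of Rho-associated protein kinase 2 (Homo sapiens); on this read-out lower numbers stand for stronger inhibition and higher numbers for weaker inhibition: 340 nM
compound 2 `CC(C)[C@@H](N)C(=O)Nc1cc2cc[nH]c(=O)c2cc1Cl`, in this assay: 240 nM

Among the compounds with values here, on these two numbers compound 2 holds the lower one, but its only neighbor is compound 1, and the step of a 1.4-fold lower number from compound 1 to compound 2 (0.15 log units; within the scatter) stays inside the scatter, so the two compounds cannot be told apart in this assay. Compound 3 `CC(C)(C)C[C@@H](N)C(=O)Nc1cc2cc[nH]c(=O)c2cc1Cl` differs from compound 2 in a single place: neopentyl in place of isopropyl on a saturated chain carbon bound to an amine nitrogen and a carbonyl carbon.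

Within the data shown here, only one measured step bears on this change. Trimming the side chain on the carbon bound to the amine nitrogen and the carbonyl carbon, from 1-amino-3-methylbutyl to 1-amino-2-methylpropyl, gave a 1.4-fold lower number from compound 1 to compound 2 (0.15 log units; within the scatter), a change too small to separate from noise. Compound 3 now lengthens that side chain again, to neopentyl. Since the one shift already tried at this position left the number essentially unchanged, compound 3 is expected to sit close to compound 2 as well, with a step of a 1.5-fold higher number from compound 2 to compound 3 (0.16 log units; within the scatter) that need not exceed the scatter. The estimate for compound 3 in this assay is 350 nM, with a range from 150 nM to 900 nM.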

Compound 3, half-maximal inhibitory concentration: 110 nM
Beside the measured number, compound 3's estimate is 3.2-fold (0.50 log units) above it; measured number outside the range, below it.
By their numbers in this assay, from the lowest: compound 3; then compounds 2 and 1 (each within the scatter of the next).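

In this assay the side chain on the saturated chain carbon bound to an amine nitrogen and a carbonyl carbon now proves able to move the number, since neopentyl in place of isopropyl gives a 2.2-fold lower number from compound 2 to compound 3 (0.34 log units; beyond the scatter) and 1-amino-3,3-dimethylbutyl in place of 1-amino-3-methylbutyl on a carbonyl carbon gives a 3.1-fold lower number from compound 1 to compound 3 (0.49 log units; beyond the scatter) as well. Both steps lie beyond the scatter, so compound 3 is the first of these compounds that can be told apart from the others, and it holds the lowest number of the three, while the 1-amino-3-methylbutyl and 1-amino-2-methylpropyl chains of compounds 1 and 2 remain indistinguishable. Nothing available explains why the neopentyl group gives this result.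

As far as these compounds go, it remains open whether a longer chain or a cyclohexylmethyl group at this place would lower the number further or reverse the gain. From the compounds shown here alone, it is also open how a hydroxyl group in place of the amine would read, and whether the neopentyl gain would hold on a core carrying something other than the chlorine.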